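The source may hold more compounds than are shown below. What is called first, only, known or untested is meant among the compounds shown, and "the series" means these compounds.

Measured so far:
compound 1 `c1coc(-c2ccccc2NCC2=NCCN2)c1` — 0.468 nM
compound 2 `Cc1nc(-c2ccccc2NCC2=NCCN2)cs1` — 4.47 nM

In a functional assay for activation of Alpha-1A adrenergic receptor (Homo sapiens), read by calcium flux (a higher number here means that more compound is needed for the effect, a lower number that less compound is needed), compound 1 gives 0.468 nM and compound 2 gives 4.47 nM. Among the compounds with values here, compound 2 stands as the higher of the two numbers; the one step between them, a 9.6-fold higher number from compound 1 to compound 2 (0.98 log units; beyond the scatter), is the only structural comparison available and concerns the exchange of one aromatic ring for another on the same carbon of the shared core. Compound 3 `c1ccc(-c2cnccn2)c(NCC2=NCCN2)c1` is not yet measured. It differs from compound 2 as follows: pyrazin-2-yl in place of 2-methyl-1,3-thiazol-4-yl on an aromatic carbon. The step from compound 1 to compound 2 is the only one that bears on such a ring swap, and it was modest. Within the data shown here, with no direct precedent for pyrazin-2-yl, a step in this assay of a 1.3-fold higher number from compound 2 to compound 3 (0.13 log units; within the scatter) is expected, with the direction uncertain. Compound 3 is therefore estimated at 6 nM, with a range from 1.5 nM to 25 nM.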

Compound 3, half-maximal effective concentration: 4.57 nM
Beside the measured number, compound 3's estimate is 1.3-fold (0.12 log units) above it; the range from low to high includes it.
By their numbers in this assay, from the lowest: compound 1; then compounds 2 and 3 (each within the scatter of the next).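

In this assay, pyrazin-2-yl and 2-methyl-1,3-thiazol-4-yl, a six-membered and a five-membered aromatic ring, cannot be told apart on this aromatic carbon: the exchange gives a 1.0-fold higher number from compound 2 to compound 3 (0.01 log units; within the scatter). The earlier compounds showed only that one ring swap here could move the number, and this pair shows that another swap need not, so ring size alone does not set the number among the listed compounds. Furan-2-yl now stands apart from both other rings, with a 9.8-fold higher number from compound 1 to compound 3 (0.99 log units; beyond the scatter) alongside a 9.6-fold higher number from compound 1 to compound 2 (0.98 log units; beyond the scatter), but no measurement here accounts for that separation.

The compounds shown leave open whether a plain phenyl ring or a thiophene ring would fall with compound 1 or with compounds 2 and 3. They also leave open how a non-aromatic group at this carbon, such as an amine or a carboxylic acid, would compare, and whether the methyl on the thiazole contributes at all.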